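From Carboxamide to Carboxylic Acid on a Shared Core

The source may hold more compounds than are shown below. What is called first, only, known or untested is meant among the compounds shown, and "the series" means these compounds.

Compound 1 `NC(=O)c1sc2nc(-c3ccccc3)cc(C(F)(F)F)c2c1N` carries a carboxamide on its core. In an ADME assay on Huh-7 cells (Homo sapiens) for cytotoxicity, read by MTT assay, with a stated time of 72 h (on this read-out lower numbers stand for higher toxicity in this test and higher numbers for lower toxicity in this test), compound 1 gives > 20000 nM, which is a limit of the assay rather than a number. Compound 2 `Nc1c(C(=O)NCc2cccs2)oc2nc(-c3ccccc3)cc(C(F)(F)F)c12` is a second member of the same series. In this assay compound 2 gives > 20000 nM, again a limit of the assay. Both readings therefore sit at the limit of > 20000 nM in this assay, at which 2 of the 2 values shown sit, so nothing can be said about any gap between them, and compound 1 stands simply at that limit.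

Compound 3 `Nc1c(C(=O)O)sc2nc(-c3ccccc3)cc(C(F)(F)F)c12` has not yet been measured in this assay. It differs from compound 1 in one place: hydroxy in place of amino on a carbonyl carbon, or carbamoyl to carboxy when the change is cut one bond further out. Among the measured compounds shown here, no step between measured compounds is available to guide the size of this change. The expected step, a number no higher from compound 1 to compound 3 (the limit leaves the size open), is none beyond the usual scatter. Compound 3 is accordingly estimated to give 20000 nM in this assay, within a range from 12000 nM to 40000 nM, and most likely to be reported once more as a limit.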

Compound 3, half-maximal cytotoxic concentration: > 20000 nM
Compound 3: only a limit was reported; the forecaster's own chance of this, stated with the estimate: 85%; the middle value sits exactly at the limit.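

In this assay compound 3 gives > 20000 nM, which is a limit of the assay and not a number. No step can be read from compound 1 to compound 3, because both stand at the same limit: the limit of > 20000 nM in this assay, at which 3 of the 3 values shown sit.

The compounds shown leave open whether hydroxy in place of amino on a carbonyl carbon changes the read-out in this assay at all.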